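Thiazolidinone series: cytotoxicity on Vero cells, methyl for methoxy

The compounds below may be only part of what the source reports. "The series", "measured", "known", "first", "only" and "open" are said of these compounds alone.

Measured so far:
- compound 1, `O=C1CSC(c2ccccc2Cl)N1CCN1CCCCC1`: 71%
- compound 2, `COc1ccc(C2SCC(=O)N2CCN2CCCCC2)cc1`: 87%
- compound 3, `COc1cccc(C2SCC(=O)N2CCN2CCCCC2)c1`: 66%

In an ADME assay on Vero cells (Chlorocebus sabaeus) for cytotoxicity, read by neutral red uptake, tested at 197 ug/mL (on this read-out higher numbers stand for a weaker effect at the one concentration tested and lower numbers for a stronger effect), compound 2 gives 87%, the highest of the three numbers. Compound 1 sits nearest with 71%, a gap beyond the scatter; compound 3 is furthest with 66%, also beyond the scatter. Compound 2 therefore shows the weakest effect of the three at the single concentration used.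

Compound 4, `Cc1ccc(C2SCC(=O)N2CCN2CCCCC2)cc1`, differs from compound 2 in one place:
methyl in place of methoxy on an aromatic carbon

For the measured compounds named here, no step between measured compounds matches this change, so the size of the step from compound 2 to compound 4 in this assay cannot be read from the series; the numbers of compound 1 and compound 3 only show that the other substituted analogues fall below compound 2. A small downward step, possibly within the scatter, is expected. The estimated step is a number 9 percentage points lower from compound 2 to compound 4 (within the scatter). For compound 4 in this assay the expected value is 78%, with a range from 62% to 92%.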

Compound 4, a percentage reported as activity, at one concentration (the size of the read-out at that concentration, not a potency): 85%
For compound 4 the middle estimate is 7 percentage points below the measured one; the measured number falls inside the stated range.
By their numbers in this assay, from the lowest: compounds 3 and 1 (each within the scatter of the next); then compounds 4 and 2 (each within the scatter of the next).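

In this assay methyl in place of methoxy, para to a large group, gives a number 2 percentage points lower from compound 2 to compound 4 (within the scatter) and so does not separate the two groups at this place; the oxygen of methoxy is not needed to keep the read-out in this range. For the compounds shown here, by contrast, 4-methylphenyl in place of 2-chlorophenyl on a saturated ring carbon gives a number 14 percentage points higher from compound 1 to compound 4 (beyond the scatter) and so moves the read-out, which makes compound 4 the first compound to tie a difference of this size to a named aryl change. No measurement at hand explains either step.

Going by these compounds, whether a carboxylic acid, an amine or a longer chain such as butyl at this place would stay level with methyl and methoxy remains open. Going by these compounds alone, with one concentration, the series also gives no potency for any compound.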